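From Benzyl to Naphthalenyl on a Reversed Amide

The source may hold more compounds than are shown below. What is called first, only, known or untested is meant among the compounds shown, and "the series" means these compounds.

Measured compounds:
compound 1 `CC(C)c1onc(-c2c(Cl)cccc2Cl)c1COc1ccc(C(=O)N(c2cccc(C(=O)O)c2)c2cccc3ccccc23)c(Cl)c1`, in a functional assay on HEK293 cells for agonist activity at Bile acid receptor (Homo sapiens), read by a luciferase reporter (a higher number here means that more compound is needed for the effect, a lower number that less compound is needed), compound 1 gives 3000 nM
compound 2 `CC(C)c1onc(-c2c(Cl)cccc2Cl)c1COc1ccc(C(=O)N(Cc2ccccc2)c2ccc(C(=O)O)cc2)c(Cl)c1`, compound 2 gives 2600 nM
compound 3 `CC(C)c1onc(-c2c(Cl)cccc2Cl)c1COc1ccc(N(Cc2ccccc2)C(=O)c2cccc(C(=O)O)c2)c(Cl)c1`, compound 3 gives only a limit, > 10000 nM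

Three compounds share a core and differ in how the amide is built and what sits on its nitrogen. Compound 1 and compound 2 carry the carboxylic acid on the aryl attached to the nitrogen, and their two values lie close to one another. Within the data shown here, compound 3 turns the amide around, with the acid on the carbonyl side, and its result is a limit of this assay rather than a number; it is the one compound that sits at the limit of > 10000 nM in this assay, at which 1 of the 3 values shown sits.

Compound 4 `CC(C)c1onc(-c2c(Cl)cccc2Cl)c1COc1ccc(N(C(=O)c2cccc(C(=O)O)c2)c2cccc3ccccc23)c(Cl)c1` keeps the reversed amide of compound 3 and changes only the group on the nitrogen: naphthalen-1-yl in place of benzyl on an amide-type nitrogen. Among the measured compounds no single step is recorded, so the size of the change from compound 3 to compound 4 is not known from the data. Since compound 3 gives only a limit, the estimate for compound 4 is set just within the measurable range, with a step estimated as an at least 1.2-fold lower number from compound 3 to compound 4 (0.09 log units; that floor lies within the scatter). Compound 4 is expected to give about 8000 nM in this assay, between 3000 nM and 20000 nM.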

Compound 4, half-maximal effective concentration: 410 nM
Compound 4: middle estimate off by 20-fold (1.29 log units), on the high side, outside the stated range (below it).
By their numbers in this assay, from the lowest: compound 4; then compounds 2 and 1 (each within the scatter of the next). At a limit, above all of these: compound 3.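

Among these compounds, on the reversed amide, the group on the nitrogen proves decisive in this assay: naphthalen-1-yl in place of benzyl gives an at least 24-fold lower number from compound 3 to compound 4 (1.38 log units; beyond the scatter), the first step in this set between compounds that differ in one place. Among the compounds shown here, compound 3 remains the only compound whose result is a limit of the assay and not a number: the limit of > 10000 nM in this assay, at which 1 of the 4 values shown sits. The step has a floor only and its full size cannot be read. Compound 4, at 410 nM, shows that a reversed amide carrying the acid on the carbonyl side can still give a measurable value.

The compounds shown leave open whether the change in value follows the second aromatic ring of naphthalen-1-yl or the loss of the benzyl methylene, a question that a plain phenyl or a naphthalen-2-yl on the same nitrogen would address. They also leave open whether the same exchange would have a similar effect on the unreversed amide, where compound 1 and compound 2 differ in more than one place and so give no clean comparison.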